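The compounds below may be only part of what the source reports. "The series", "measured", "known", "first", "only" and "open" are said of these compounds alone.

Measured so far:
- compound 1, `COc1ccc(S(=O)(=O)N2CCc3cccc(Nc4ccc(O)cc4)c32)cc1`, 511 nM
- compound 2, `COc1ccc(Nc2cccc3c2N(S(=O)(=O)c2ccc(OC)cc2)CC3)cc1`, 803 nM
- compound 3, `COC(=O)c1ccc(Nc2cccc3c2N(S(=O)(=O)c2ccc(OC)cc2)CC3)cc1`, 678 nM

All three numbers come from a functional assay on HT-29 cells (Homo sapiens) for antiproliferative activity; on this read-out higher numbers stand for weaker inhibition and lower numbers for stronger inhibition; in this assay compound 1 gives 511 nM, compound 2 gives 803 nM and compound 3 gives 678 nM. The three values lie within the scatter of one another, so no order among them is claimed: a 1.6-fold lower number from compound 2 to compound 1 (0.20 log units; within the scatter), a 1.3-fold higher number from compound 1 to compound 3 (0.12 log units; within the scatter), a 1.2-fold lower number from compound 2 to compound 3 (0.07 log units; within the scatter).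

Compound 4, `COc1ccc(S(=O)(=O)N2CCc3cccc(Nc4ccc(C(=O)O)cc4)c32)cc1`, is not yet measured. It differs from compound 3 by hydrogen in place of methyl on an oxygen next to a carbonyl group. The same kind of change has been made once already, from compound 2 to compound 1: hydrogen in place of methyl on an oxygen on an aromatic ring, which gave a 1.6-fold lower number from compound 2 to compound 1 (0.20 log units; within the scatter). The cores of compound 2 and compound 3 differ by methoxycarbonyl in place of methoxy on an aromatic carbon. The place of the change is not the same in the two pairs: in the measured pair it is on an oxygen on an aromatic ring whose other neighbours are an aromatic carbon, in the new pair on an oxygen next to a carbonyl group whose other neighbours are the carbonyl carbon, so it counts as the same kind of change, not the same change.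

For compound 4 the expected step is a 1.2-fold higher number from compound 3 to compound 4 (0.07 log units; within the scatter), placed beside a 1.6-fold lower number from compound 2 to compound 1 (0.20 log units; within the scatter), resting on that single earlier step and on the fact that the place differs; with one precedent the range is kept wide. The estimate for compound 4 in this assay is 800 nM, between 300 nM and 2500 nM.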

Compound 4, half-maximal inhibitory concentration: 2380 nM
Compound 4: the middle estimate sits 3.0-fold (0.47 log units) below what was measured; measured number inside the range.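

In this assay, hydrogen in place of methyl on the oxygen next to a carbonyl group gives a 3.5-fold higher number from compound 3 to compound 4 (0.55 log units; beyond the scatter), and the carboxy compound also stands apart from the other two: a 3.0-fold higher number from compound 2 to compound 4 (0.47 log units; beyond the scatter), and a 4.7-fold higher number from compound 1 to compound 4 (0.67 log units; beyond the scatter). The change does not carry from one core to the other in this series, as the two steps differ: the same change on two cores in this assay, a 1.6-fold lower number (0.20 log units; within the scatter) from compound 2 to compound 1 and a 3.5-fold higher number (0.55 log units; beyond the scatter) from compound 3 to compound 4, 5.5-fold (0.74 log units) apart, beyond the scatter of two such steps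

Within the data shown here, this shows that the step on the oxygen on an aromatic ring gave no guide to the step on the oxygen next to a carbonyl group; with one pair for each place, it does not show whether the place of the change or the rest of the structure sets the gap, and it gives no general rule for the change.

On these data alone, it remains open whether the higher number is particular to the carboxy group or also appears with a primary amide or an amine on that aromatic carbon. As far as these compounds go, the effect of a longer chain on the ester oxygen, such as ethyl, also remains open.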